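A few compounds are considered here, and "the series" means these few. Any claim that something is new, unique, unknown or untested is made for them only; others in the source may bear on it.

Of the compounds shown here, two have so far been tested in an ADME assay on cells (Macrophage, Mus musculus) for cytotoxicity, read by resazurin assay, with a stated time of 3 days; a higher number here means a weaker inhibitor, a lower number a stronger inhibitor. Compound 1 `O=C(Nc1cc(C(F)(F)F)cc(C(F)(F)F)c1)c1ccccc1Cl` gives > 1700 nM, which is a limit of the assay and not a number. Among the compounds with values here, compound 2 `O=C(Nc1cccc(C(F)(F)F)c1)c1cc(Cl)ccc1O` gives 5900 nM, the only actual number available, so its standing cannot yet be judged against a second measured value. Compound 3 `O=C(Nc1cccc(C(F)(F)F)c1C(F)(F)F)c1cc(Cl)ccc1O` keeps the structure of compound 2 except at one place: trifluoromethyl in place of hydrogen on an aromatic carbon. There, a trifluoromethyl stands in place of hydrogen on an aromatic carbon, ortho to a trifluoromethyl group. Within the data shown here, no step between measured compounds is available to show what such a change does in this assay, so any forecast is uncertain. A modest move towards a lower number is expected, meaning a somewhat stronger effect on the cells, and it may well stay within the usual scatter. The estimated 1.5-fold lower number from compound 2 to compound 3 (0.17 log units; within the scatter) is correspondingly small. This expectation is anchored on compound 2 at 5900 nM. For compound 3 the estimated value is 4000 nM, with an expected range from 1500 nM to 11000 nM.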

Compound 3, half-maximal inhibitory concentration: 8100 nM
Compound 3: the middle estimate sits 2.0-fold (0.31 log units) below what was measured, and the stated range covers the measured number.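

In this assay, this position now has its first readable step, a 1.4-fold higher number from compound 2 to compound 3 (0.14 log units; within the scatter), for trifluoromethyl in place of hydrogen on an aromatic carbon, ortho to a trifluoromethyl group. The earlier compounds shown here offered no such step, and this one shows that, on the core of compound 2, the added group leaves the two compounds indistinguishable in this read-out, since the step lies within the scatter. Compound 1 cannot sharpen this picture, as it differs from the others in more than one place and its reading is a limit of the assay and not a number: the limit of > 1700 nM in this assay, at which 1 of the 3 values shown sits.

As far as these compounds go, this is a single step on a single core, so it remains open whether the same replacement would stay within the scatter on another core, such as that of compound 1. From the compounds shown here alone, it is equally open whether a different group at this position, such as an amine, a carboxylic acid or a longer alkyl chain, would move the reading beyond the scatter in either direction, and so whether the position is insensitive in general or only to trifluoromethyl.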